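The source may report more compounds than this note shows. Statements on the series, on what has been measured and on what is new or still open speak of the compounds shown alone.

Measured compounds:
- compound 1, `Nc1nc(Cl)c(-c2cccs2)c(N[C@@H]2C[C@H](CO)[C@@H](O)[C@H]2O)n1` — in an ADME assay on cells (Homo sapiens) for cytotoxicity, read by polymerase chain reaction, with a stated time of 3 days (a higher number here means that more compound is tolerated, a lower number that less compound is tolerated), compound 1 reports only a limit, > 25000 nM.
- compound 2, `CNc1ccc2nc(-c3c(Cl)nc(N)nc3N[C@@H]3C[C@H](CO)[C@@H](O)[C@H]3O)sc2c1` — in this assay compound 2 gives 6000 nM.
- compound 3, `CCCNc1nc(C)c(-c2nc3ccccc3s2)c(N[C@@H]2C[C@H](CO)[C@@H](O)[C@H]2O)n1` — in this assay compound 3 reports only a limit, > 25000 nM.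

Compound 3 thus stands at the upper edge of what this assay can report: its value is a limit and not a number, and the same holds for compound 1, so that two of the three results shown are limits (the limit of > 25000 nM in this assay, at which 2 of the 3 values shown sit). Going by the values given here, compound 2 is the only member of the set with a numerical result. No pair of these compounds differs in a single place, so no measured step is available within the series.

The next compound, compound 4, `Cc1nc(NCC2CC2)nc(N[C@@H]2C[C@H](CO)[C@@H](O)[C@H]2O)c1-c1nc2ccccc2s1`, is to be measured in this assay. Its difference from compound 3 is cyclopropyl in place of ethyl on a saturated chain carbon bound to a nitrogen on an aromatic ring, or, cut one bond further out, propyl to cyclopropylmethyl on the aromatic amine. No change in donors, acceptors or charge is counted.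

Among the compounds with values here, with compound 3 already at a limit and no measured step to lean on, the expectation is no shift beyond the scatter; the step from compound 3 to compound 4 is estimated as a number no higher from compound 3 to compound 4 (the limit leaves the size open). Compound 4 is therefore expected at about 25000 nM, within 12000 nM to 60000 nM, most likely reported again as a limit.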

Compound 4, half-maximal cytotoxic concentration: 8000 nM
The estimate for compound 4 lay 3.1-fold (0.49 log units) above the measured number; measured number below the stated range.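

In this assay, cyclopropyl in place of ethyl on a saturated chain carbon bound to a nitrogen on an aromatic ring gives an at least 3.1-fold lower number from compound 3 to compound 4 (0.49 log units; beyond the scatter). Going by these compounds alone, this is the first measured step, and it shows that the group on this amine can bring a compound from the limit to a numerical result, although no change in donors, acceptors or charge is counted. Compound 3 reports only a limit, > 25000 nM, and the full size of the step stays open because it starts from that limit: the limit of > 25000 nM in this assay, at which 2 of the 4 values shown sit.

As far as these compounds go, whether the lower number follows the three-membered ring itself or simply the larger group remains open, and a butyl chain or a cyclobutylmethyl group at this place would help separate the two. From the compounds shown here alone, with a single step on one core, it is also open whether the change from propyl to cyclopropylmethyl would have the same effect on other members.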